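Swapping a thiophene for a thiazole on a hepatic extraction series

A few compounds are considered here, and "the series" means these few. Any claim that something is new, unique, unknown or untested is made for them only; others in the source may bear on it.

Of the compounds shown here, two have been tested so far in an ADME assay on microsomes from liver (Mus musculus), read by LC-MS, using NADPH, tested at 10 uM; on this read-out higher numbers stand for higher hepatic extraction and lower numbers for lower hepatic extraction. Compound 1, with the structure `Cc1ccccc1S(=O)(=O)N1CCN(c2ccc(C(=O)NCc3cccs3)nn2)CC1`, gives 0.97, the higher of the two numbers. Compound 2, with the structure `O=C(NCc1ccccc1)c1ccc(N2CCC(S(=O)(=O)c3cccc(Cl)c3Cl)CC2)nn1`, gives 0.75 in this assay, a gap that lies beyond the usual scatter of repeated measurements. Among the compounds with values here, the two compounds differ in several places at once, so their pair offers no single step to learn from.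

Compound 3, with the structure `Cc1ccccc1S(=O)(=O)N1CCN(c2ccc(C(=O)NCc3cncs3)nn2)CC1`, has not yet been measured. It differs from compound 1 in one place only: 1,3-thiazol-5-yl in place of thiophen-2-yl on a saturated chain carbon bound to an amide-type nitrogen. Within the data shown here, no measured pair shows what this particular swap does, so the expectation rests on how compound 1 stands alone. Since compound 1 already gives 0.97, there is little room for compound 3 to move upward, and any change beyond the scatter would have to be a fall. The step from compound 1 to compound 3 is expected to be small, about a number 0.070 lower from compound 1 to compound 3 (within the scatter), and may not exceed the scatter. Compound 3 is therefore estimated to give 0.9 in this assay, within a range from 0.75 to 0.99.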

Compound 3, hepatic extraction ratio: 0.77
Beside the measured number, compound 3's estimate is 0.13 above it, and the stated range covers the measured number.
By their numbers in this assay, from the lowest: compounds 2 and 3 (each within the scatter of the next); then compound 1.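

In this assay the exchange of thiophen-2-yl for 1,3-thiazol-5-yl on a saturated chain carbon bound to an amide-type nitrogen gives a number 0.20 lower from compound 1 to compound 3 (beyond the scatter), which shows that the number responds to the ring at this position. The two rings have the same count of heavy atoms: one carbon gives way to one nitrogen, which adds a second hetero atom and a second hydrogen-bond acceptor, and that single edit is enough to produce a step beyond the usual scatter. No evidence at hand explains why hepatic extraction falls with this change.

With only this one swap shown at this position, it remains open whether a pyridin-3-yl or a furan-2-yl group on the same chain carbon would give a number near that of compound 1 or near that of compound 3. As far as these compounds go, it also remains open whether the same thiophen-2-yl to 1,3-thiazol-5-yl exchange would give a step of similar size on a different core, since a single pair cannot show how far this result carries.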